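This account rests on a few compounds, and the source may have more. Where it says the series, first, only, none or still open, it means among the compounds named here.

Compound 2 `Cc1cc(-c2sc(Cc3cccc(Cl)c3)nc2C)ccc1C(N)=O` gives the lower of the two numbers obtained so far in a functional assay on cells for agonist activity at G-protein coupled receptor 52 (Homo sapiens), read by AlphaScreen and cAMP accumulation, with a stated time of 30 min (on this read-out lower numbers stand for an effect already at smaller amounts and higher numbers for an effect only at larger amounts of compound), namely 130 nM, while compound 1 `Cc1cc(-c2sc(Cc3cccc(F)c3)nc2C)ccc1C(N)=O` gives 260 nM; the step of a 2.0-fold lower number from compound 1 to compound 2 (0.30 log units; within the scatter) stays within the scatter. Compound 3 `Cc1cc(-c2sc(Cc3ccc(Cl)cc3)nc2C)ccc1C(N)=O` differs from compound 2 by 4-chlorophenyl in place of 3-chlorophenyl on a saturated chain carbon bound to an aromatic carbon. Going by the values given here, no measured step moves the chlorine to another place on the ring; the only step known swaps one halogen for another and was small. For compound 3 the expected change is therefore a 1.2-fold higher number from compound 2 to compound 3 (0.06 log units; within the scatter), with no direction favoured. Compound 3 is estimated at 150 nM, between 45 nM and 500 nM.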

Compound 3, half-maximal effective concentration: 210 nM
Estimate against measurement, compound 3: 1.4-fold (0.15 log units) below; the range from low to high includes it.
By their numbers in this assay, from the lowest: compounds 2, 3 and 1 (each within the scatter of the next).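

Moving the chlorine, with 4-chlorophenyl in place of 3-chlorophenyl, gives a 1.6-fold higher number from compound 2 to compound 3 (0.21 log units; within the scatter) in this assay, so the two chlorine placements on this ring cannot be told apart. Changing halogen and placement together, with 4-chlorophenyl in place of 3-fluorophenyl, gives a 1.2-fold lower number from compound 1 to compound 3 (0.09 log units; within the scatter) and also stays within the scatter. Nothing at hand offers an explanation for these small steps. Still open, as far as these compounds go, is whether an amine, a carboxylic acid or a longer chain on this ring would move the number beyond the scatter.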